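The source may report more compounds than this note shows. Statements on the series, on what has been measured and on what is new or still open speak of the compounds shown alone.

Compound 1 `Cc1cnc2nc(-c3ccc(F)cc3)cc(O)c2c1` gives 33900 nM in a functional assay on NCI-H460 cells (Homo sapiens) (a higher number here means a weaker inhibitor of growth, a lower number a stronger inhibitor of growth), the highest of the three numbers recorded for the series. Compound 3 `Cc1cnc2nc(-c3ccc(Cl)cc3)cc(O)c2c1` gives 3890 nM, and compound 2 `COc1cccc(-c2cc(O)c3c(C)ccnc3n2)c1` gives 47.9 nM, the lowest of the three. Among the measured compounds shown here, the only measured step from compound 1 is an 8.7-fold lower number from compound 1 to compound 3 (0.94 log units; beyond the scatter), a modest change beyond the scatter. Compound 4 `Oc1cc(-c2ccc(F)cc2)nc2ncc(Cl)cc12` alters compound 1 at a different place: chloro in place of methyl on an aromatic carbon. For the measured compounds named here, no measured pair exchanges methyl for chloro, and none varies this position of the shared core, so direct guidance is absent. The step of an 8.7-fold lower number from compound 1 to compound 3 (0.94 log units; beyond the scatter) is the nearest analogy: a chloro entering the molecule went together with a lower number in this assay , though on another ring. A downward step of smaller size than that one is therefore expected for compound 4, with real possibility that it stays within the scatter. The expected step is a 2.3-fold lower number from compound 1 to compound 4 (0.35 log units; beyond the scatter). Compound 4 is estimated at 15000 nM, within a range from 4000 nM to 50000 nM.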

Compound 4, concentration for 50% growth inhibition: 30200 nM
Estimate against measurement, compound 4: 2.0-fold (0.30 log units) below; the range from low to high includes it.
By their numbers in this assay, from the lowest: compound 2; then compound 3; then compounds 4 and 1 (each within the scatter of the next).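

In this assay the exchange of methyl for chloro gives a 1.1-fold lower number from compound 1 to compound 4 (0.05 log units; within the scatter) and so leaves the number unmoved on this aromatic carbon, two atoms from the ring nitrogen, with the rest of compound 1 unchanged. A chloro entering therefore does not go with a lower number everywhere in the series: the step of an 8.7-fold lower number from compound 1 to compound 3 (0.94 log units; beyond the scatter) on the other ring stays beyond the scatter, though there chloro replaces fluoro and not methyl. Nothing on hand accounts for this difference between the two places.

Going by these compounds, whether any group at this position moves the number remains open, for instance an amine or a carboxylic acid in place of the methyl. Also open, on these data alone, is whether methyl and chloro still read alike here when the other ring carries the chloro of compound 3.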